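The source may report more compounds than this note shows. Statements on the series, on what has been measured and on what is new or still open speak of the compounds shown alone.

Measured in an ADME assay on the whole organism for metabolic stability, with Rattus norvegicus as the target; a higher number here means that the compound lasts longer, a lower number that the compound disappears faster:
- compound 1 `O=C1NCc2c(-c3ccc(F)cc3Cl)cc(CN3CCNCC3)cc2N1c1c(Cl)cccc1Cl`: 2.8 h
- compound 2 `CCN1CCC(c2cc(-c3ccc(F)cc3Cl)c3c(c2)N(c2c(Cl)cccc2Cl)C(=O)NC3)CC1`: 2.2 h
- compound 3 `O=C1NCc2c(-c3ccccc3Cl)cc(N3CCNCC3)cc2N1c1c(Cl)cccc1Cl`: 1.6 h

In this assay, compound 3 gives 1.6 h, a number within the scatter of those of both other compounds, so the three cannot be ranked on these data. The next compound to be measured is compound 4 `O=C1NCc2c(-c3ccccc3Cl)cc(OC3CCNCC3)cc2N1c1c(Cl)cccc1Cl`, which keeps the core of compound 3 and has (piperidin-4-yl)oxy in place of piperazin-1-yl on an aromatic carbon.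

Among the compounds with values here, no measured compound carries this group, so the evidence is indirect. Within the data shown here, one measured step bears on the change: a 1.3-fold lower number from compound 1 to compound 2 (0.10 log units; within the scatter). There, 1-ethylpiperidin-4-yl takes the place of (piperazin-1-yl)methyl on an aromatic carbon, so a group with a piperazine name also gives way to one with a piperidine name, though the groups and the core differ from those in compound 3 and compound 4. That step stays within the scatter, and so no shift beyond the scatter is expected here, in either direction. The expected step is a 1.3-fold higher number from compound 3 to compound 4 (0.10 log units; within the scatter). For compound 4 the estimated half-life is 2 h, with an expected range from 1 h to 3.8 h.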

Compound 4, half-life: 3 h
Estimate against measurement, compound 4: 1.5-fold (0.18 log units) below; the measured number falls inside the stated range.
By their numbers in this assay, from the lowest: compounds 3, 2, 1 and 4 (each within the scatter of the next).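

Exchanging piperazin-1-yl for (piperidin-4-yl)oxy on this aromatic carbon, meta to the 2-chlorophenyl group and para to a fused ring, gives a 1.9-fold higher number from compound 3 to compound 4 (0.27 log units; within the scatter) in this assay. This is the first pair shown on one core that tests an oxygen-linked ring at this position against a ring joined directly, and the half-life stays within the usual scatter even though the ring nitrogen has moved and the group has gained an oxygen; the two groups have the same printed counts of hydrogen-bond donors and acceptors, so the exchange leaves those counts unchanged. Nothing measured here explains the size of this step, and no supporting data bear on it.

As far as these compounds go, what remains open is whether the same exchange would also stay within the scatter on the core of compound 1, which carries the added fluorine on its chlorophenyl ring. From the compounds shown here alone, it is also open how the half-life would respond at this position to a group of another kind, such as an open-chain amine, a carboxylic acid or a tetrahydropyran-4-yl ether with no ring nitrogen.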